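The source may hold more compounds than are shown below. What is called first, only, known or untested is meant among the compounds shown, and "the series" means these compounds.

Measured so far:
compound 1, `CC(C)c1ncncc1-c1nc2cc(F)c(F)cc2n1C1CC1`, in an assay on cells for inhibition of cytochrome P450 11B2, mitochondrial (Homo sapiens), read by HPLC, with a stated time of 90 min; a higher number here means a weaker inhibitor, a lower number a stronger inhibitor: 5 nM
compound 2, `Fc1cc2nc(-c3cncnc3C3CC3)n(C3CC3)c2cc1F`: 172 nM
compound 3, `CN(C)c1ncncc1-c1nc2cc(F)c(F)cc2n1C1CC1`: 29 nM

All three share one core and differ only in the group on one aromatic carbon of the six-membered ring with two nitrogens. Compound 3 stands second highest of the three numbers in this assay: its nearest neighbour is compound 1 (a 5.8-fold higher number from compound 1 to compound 3 (0.76 log units; beyond the scatter)), its furthest compound 2 (a 5.9-fold lower number from compound 2 to compound 3 (0.77 log units; beyond the scatter)). Compound 4, `Fc1cc2nc(-c3cncnc3C(F)F)n(C3CC3)c2cc1F`, is not yet measured; the change from compound 3 is difluoromethyl in place of dimethylamino on an aromatic carbon. The two measured steps that touch dimethylamino bear on this change, a 5.8-fold higher number from compound 1 to compound 3 (0.76 log units; beyond the scatter) and a 5.9-fold lower number from compound 2 to compound 3 (0.77 log units; beyond the scatter), both of modest size, while a 34-fold higher number from compound 1 to compound 2 (1.54 log units; beyond the scatter) shows how much a change at this one carbon can move the number. Within the data shown here, no measured step involves difluoromethyl, so the direction rests on this spread alone. The expected step is a 2.1-fold higher number from compound 3 to compound 4 (0.32 log units; beyond the scatter), toward a weaker inhibitor. The estimate for compound 4 is 60 nM, with a range from 15 nM to 250 nM.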

Compound 4, half-maximal inhibitory concentration: 18 nM
For compound 4 the middle estimate is 3.3-fold (0.52 log units) above the measured one; measured number inside the range.
By their numbers in this assay, from the lowest: compound 1; then compounds 4 and 3 (each within the scatter of the next); then compound 2.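

In this assay difluoromethyl and dimethylamino cannot be told apart at this carbon, with a 1.6-fold lower number from compound 3 to compound 4 (0.21 log units; within the scatter) between them, although dimethylamino counts one hydrogen-bond acceptor and difluoromethyl none. Difluoromethyl stands clear of the other two groups, with a 9.6-fold lower number from compound 2 to compound 4 (0.98 log units; beyond the scatter) on one side and a 3.6-fold higher number from compound 1 to compound 4 (0.56 log units; beyond the scatter) on the other, so isopropyl keeps the lowest number of the four and cyclopropyl the highest. No measurement shown accounts for these differences.

The compounds shown leave open how trifluoromethyl, methoxy, ethyl or a cyclic amine such as pyrrolidine would compare at this carbon. They also leave open whether the same order of groups would hold if the two fluorines or the cyclopropyl elsewhere on the shared core were replaced.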